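The source may hold more compounds than are shown below. What is called first, only, known or untested is meant among the compounds shown, and "the series" means these compounds.

Compound 3 `COc1cccc(Oc2c(NS(=O)(=O)c3ccc(C(C)(C)C)cc3)ncnc2OCCOc2ccncn2)c1` gives 1.2 nM in an assay on cells (Endothelial cell) for binding affinity to Endothelin-1 receptor (Sus scrofa) (on this read-out higher numbers stand for weaker inhibition and lower numbers for stronger inhibition), the lowest of the three numbers. Compound 2 `COc1cccc(Oc2c(NS(=O)(=O)c3ccc(C(C)(C)C)cc3)ncnc2OCCOc2ncccn2)c1` gives 1.9 nM and compound 1 `COc1cccc(Oc2c(NS(=O)(=O)c3ccc(C(C)(C)C)cc3)ncnc2OCCOCc2ccccc2)c1` gives 170 nM. Compound 4 `COc1cccc(Oc2c(NS(=O)(=O)c3ccc(C(C)(C)C)cc3)ncnc2OCCOc2nccs2)c1` differs from compound 3 by 1,3-thiazol-2-yl in place of pyrimidin-4-yl on an oxygen on a saturated carbon. The large steps of an 89-fold lower number from compound 1 to compound 2 (1.95 log units; beyond the scatter) and a 140-fold lower number from compound 1 to compound 3 (2.15 log units; beyond the scatter) concern the exchange of benzyl for a six-membered heteroaromatic ring; the step of a 1.6-fold lower number from compound 2 to compound 3 (0.20 log units; within the scatter) shows that moving between two such rings hardly matters. Among the measured compounds shown here, no measured step exchanges a six-membered heteroaromatic ring for a five-membered one, so the change to compound 4 is only loosely covered. Because the step of a 1.6-fold lower number from compound 2 to compound 3 (0.20 log units; within the scatter) is within the scatter, compound 4 is expected to stay close to compound 3, with a step of a 1.7-fold higher number from compound 3 to compound 4 (0.22 log units; within the scatter). The estimate for compound 4 is 2 nM, between 0.6 nM and 7 nM.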

Compound 4, half-maximal inhibitory concentration: 12 nM
The estimate for compound 4 lay 6.0-fold (0.78 log units) below the measured number, and the stated range ends below it.
By their numbers in this assay, from the lowest: compounds 3 and 2 (each within the scatter of the next); then compound 4; then compound 1.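

On an oxygen on a saturated carbon, the heteroaromatic ring proves not to be freely exchangeable: 1,3-thiazol-2-yl falls behind pyrimidin-4-yl (a 10-fold higher number from compound 3 to compound 4 (1.00 log units; beyond the scatter)) and pyrimidin-2-yl (a 6.3-fold higher number from compound 2 to compound 4 (0.80 log units; beyond the scatter)), although those two groups lie within the scatter of each other. It still gives a lower number than benzyl (a 14-fold lower number from compound 1 to compound 4 (1.15 log units; beyond the scatter)). No measured property is available to explain the difference between these rings.

The compounds shown leave open whether pyridin-2-yl or phenyl on this oxygen would track the pyrimidinyl groups or 1,3-thiazol-2-yl. They also leave open whether 1,3-oxazol-2-yl would match 1,3-thiazol-2-yl.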